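The source may report more compounds than this note shows. Statements on the series, on what has been measured and on what is new or still open speak of the compounds shown alone.

Measured in an ADME assay on L02 cells (Homo sapiens) for cytotoxicity, read by MTT assay; on this read-out lower numbers stand for stronger inhibition and higher numbers for weaker inhibition:

Compound 1 `COc1ccc(/C=C/C(=O)c2ccc(OC)c3c2OC(C)(C)C=C3)cc1OCC=C(C)C`: > 10000 nM, a limit.
Compound 2 `C#CCOc1cc(/C=C/C(=O)c2ccc(OC)c3c2OC(C)(C)C=C3)ccc1OC`: > 10000 nM, a limit.
Compound 3 `COc1ccc(/C=C/C(=O)c2ccc(OC)c3c2OC(C)(C)C=C3)cc1OCCO`: > 10000 nM, a limit.

For the measured compounds named here, none of these three readings is a number, and the limit of > 10000 nM in this assay, at which 3 of the 3 values shown sit, sums up the series so far. Compound 3 therefore has no exact place in the series. It stands at > 10000 nM, which is a limit of the assay.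

Compound 4 `COc1ccc(/C=C/C(=O)c2ccc(OC)c3c2OC(C)(C)C=C3)cc1OC(=O)C(C)C` keeps the shared core and carries isopropylcarbonyl in place of 2-hydroxyethyl on an oxygen on an aromatic ring.

Three measured steps come closest to this change, as each swaps groups on the chain that compound 3 carries on that oxygen. They are a step that the two limits leave unreadable from compound 1 to compound 2, a step that the two limits leave unreadable from compound 1 to compound 3 and a step that the two limits leave unreadable from compound 2 to compound 3. Going by the values given here, none of them has a readable size, and all three changes lie further out on the chain than the one made in compound 4. They offer no sign of a move in either direction in this assay, so no shift beyond the scatter is expected, and another report at the limit is the likeliest outcome.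

The expected change is a step that the limit leaves unreadable from compound 3 to compound 4. For compound 4 the estimated value is 12000 nM, with an expected range from 6000 nM to 30000 nM.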

Compound 4, half-maximal inhibitory concentration: > 10000 nM
Compound 4 ended at the assay's limit; the forecaster's own chance of this, stated with the estimate: 85%; the middle value does not contradict the limit.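

In this assay compound 4 gives > 10000 nM, which is a limit. Its steps from compound 1, compound 2 and compound 3 cannot be read, and one reading sums up the series: the limit of > 10000 nM in this assay, at which 4 of the 4 values shown sit. The compounds shown leave open what exact value any of the four has, and whether any group on this oxygen on an aromatic ring changes it.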